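The compounds below may be only part of what the source reports. "The series", "measured", "known", "first", "only" and "open" are said of these compounds alone.

In a functional assay on HepG2 cells (Homo sapiens) for cytotoxicity, read by sulforhodamine B assay, with a stated time of 48 h (on this read-out lower numbers stand for stronger inhibition and higher numbers for weaker inhibition), compound 1 `COc1ccc(/C=C/C(=O)c2cccc(-c3ccc(F)cc3)c2)cc1` gives 5650 nM, compound 2 `COc1ccc(/C=C/C(=O)c2ccc(N)c(-c3ccc(F)cc3)c2)cc1` gives 3750 nM and compound 3 `COc1ccc(/C=C/C(=O)c2cccc(-c3cccc(F)c3)c2)cc1` gives 1720 nM. Compound 1 thus holds the highest of these three numbers, although only its gap to compound 3 lies beyond the scatter.

Compound 4 `COc1ccc(/C=C/C(=O)c2cccc(-c3ccc(F)cc3)c2)cc1OC` has not yet been measured. It differs from compound 1 by methoxy in place of hydrogen on an aromatic carbon, ortho to a methoxy group and meta to a large group: methoxy in place of hydrogen on an aromatic carbon.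

Within the data shown here, no measured step makes this exact change. The closest in kind is amino in place of hydrogen on an aromatic carbon, which gives a 1.5-fold lower number from compound 1 to compound 2 (0.18 log units; within the scatter). The other step, 3-fluorophenyl in place of 4-fluorophenyl on an aromatic carbon, gives a 3.3-fold lower number from compound 1 to compound 3 (0.52 log units; beyond the scatter), but it adds no group and so bears on the change only as a guide to how far one alteration can move the number in this series. With so little to go on, a small shift toward lower numbers is expected, with no step beyond the scatter.

The expected change is a 1.4-fold lower number from compound 1 to compound 4 (0.15 log units; within the scatter). For compound 4 the estimated value is 4000 nM, with an expected range from 1500 nM to 10000 nM.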

Compound 4, half-maximal inhibitory concentration: 5370 nM
For compound 4 the middle estimate is 1.3-fold (0.13 log units) below the measured one; low and high end bracket the measured number.
By their numbers in this assay, from the lowest: compound 3; then compounds 2, 4 and 1 (each within the scatter of the next).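

In this assay, methoxy in place of hydrogen on an aromatic carbon, ortho to a methoxy group and meta to a large group, gives a 1.1-fold lower number from compound 1 to compound 4 (0.02 log units; within the scatter). Among these compounds, the earlier steps changed other places on the core of compound 1, so this is the first reading at this carbon, and it shows that a group of this kind can be added there without a shift that stands out from the scatter; the added amino group of the earlier step, with a 1.5-fold lower number from compound 1 to compound 2 (0.18 log units; within the scatter), likewise stayed within the scatter, while only the move of the fluorine, with a 3.3-fold lower number from compound 1 to compound 3 (0.52 log units; beyond the scatter), went beyond it. Nothing at hand explains why the number holds at this position.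

A single group at a single carbon cannot show whether this result belongs to methoxy or to the position itself, and a hydroxyl group, an amine or a longer chain such as ethoxy at the same carbon would separate the two. From the compounds shown here alone, it also remains open whether the added methoxy would behave the same way on the 3-fluorophenyl core of compound 3, which has the lowest number here.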